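A few compounds are considered here, and "the series" means these few. Any claim that something is new, unique, unknown or untested is made for them only; others in the source may bear on it.

Notes on the series in an assay on isolated protein for inhibition of RAC-beta serine/threonine-protein kinase (Homo sapiens), read by mobility shift assay, tested at 30 uM; on this read-out higher numbers stand for more inhibition at the one concentration tested (going by the name of the read-out) and lower numbers for less inhibition.

Compound 1 `COc1ccc(-c2cc3[nH]nc(N)c3c(=O)[nH]2)cc1` and compound 2 `COc1ccc(-c2cc3c(c(N)nn3C)c(=O)[nH]2)cc1` share one core; compound 3 `Cc1cc2c(cn1)c(N)nn2C` and compound 4 `Cc1cc2[nH]nc(N)c2cn1` share another. The difference between the two cores is not broken down here. In this assay compound 1 gives 11%, compound 2 gives -8% and compound 3 gives -2%. Compound 2 and compound 3 lie within the scatter of each other; the gap from compound 3 to compound 1 lies beyond it.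

For the measured compounds named here, the one measured instance of the change is hydrogen in place of methyl on an aromatic nitrogen, which gives a number 19 percentage points higher from compound 2 to compound 1 (beyond the scatter). Compound 4 is not yet measured. It differs from compound 3 by hydrogen in place of methyl on an aromatic nitrogen, the same change at a place described in the same words, but set on the other core. The expectation for compound 4 is therefore a number 12 percentage points higher from compound 3 to compound 4 (beyond the scatter), somewhat smaller than the measured step because the step of a number 19 percentage points higher from compound 2 to compound 1 (beyond the scatter) was seen on one core only and a single measured step carries its own scatter. From this compound 4 is estimated at 10%, expected to fall between -5% and 25%.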

Compound 4, a percentage reported as inhibition, at one concentration (the size of the read-out at that concentration, not a potency): -3%
Beside the measured number, compound 4's estimate is 13 percentage points above it; the measured number falls inside the stated range.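

On the second core, hydrogen in place of methyl on an aromatic nitrogen gives a number 1 percentage points lower from compound 3 to compound 4 (within the scatter) in this assay. Set beside the earlier step, the same change does not carry over from one core to the other at the same size: the same change on two cores in this assay, a number 19 percentage points higher (beyond the scatter) from compound 2 to compound 1 and a number 1 percentage points lower (within the scatter) from compound 3 to compound 4, 20 percentage points apart, beyond the scatter of two such steps. This shows that a step measured on one core cannot simply be transferred to the other in this series, but it rests on a single pair per core and does not show which feature of the cores separates the two results.

On these data alone, only hydrogen and methyl appear on that aromatic nitrogen, so the outcome with an ethyl group or a longer chain there remains open on both cores. Also open, as far as these compounds go, is whether replacing the amino group with a carboxylic acid or an amide would change the numbers in this assay, and whether the difference between the two steps would persist.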